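This account rests on a few compounds, and the source may have more. Where it says the series, first, only, none or still open, it means among the compounds named here.

Measured compounds in an ADME assay on Vero cells (Chlorocebus sabaeus) for cytotoxicity, read by MTT assay, with a stated time of 72 h; on this read-out lower numbers stand for higher toxicity in this test and higher numbers for lower toxicity in this test:
Compound 1 `O=C(/C=C/c1ccco1)Nc1nnc(-c2ccccc2)[nH]1` gives 2180000 nM.
Compound 2 `O=C(/C=C/c1ccc(OC(F)(F)F)cc1)Nc1nnc(-c2ccccc2)[nH]1` gives 1560000 nM.
Compound 3 `O=C(/C=C/c1ccc([N+](=O)[O-])s1)Nc1nnc(-c2ccccc2)[nH]1` gives 1670000 nM.

Among the compounds with values here, on these numbers compound 3 sits inside the scatter of both others: nearest to it is compound 2, furthest compound 1, and no pair of the three is parted by more than the scatter. Compound 4 `COc1ccc(/C=C/C(=O)Nc2nnc(-c3ccccc3)[nH]2)cc1` differs from compound 3 by 4-methoxyphenyl in place of 5-nitrothiophen-2-yl on a double-bonded chain carbon bound to a double-bonded chain carbon. Within the data shown here, the one measured step at the same place, a 1.3-fold lower number from compound 1 to compound 3 (0.12 log units; within the scatter), stayed within the scatter, and compound 2, which also carries a six-membered aromatic ring of carbon only at that place, lies within the scatter of compound 3. Hence no step beyond the scatter is expected in this assay for compound 4, in either direction. Compound 4 is estimated at 1800000 nM, with a range of 900000 nM to 3600000 nM. This estimate implies a 1.1-fold higher number from compound 3 to compound 4 (0.03 log units; within the scatter), a step expected to stay within the scatter.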

Compound 4, half-maximal cytotoxic concentration: 1280000 nM
Estimate against measurement, compound 4: 1.4-fold (0.15 log units) above; the measured number falls inside the stated range.
By their numbers in this assay, from the lowest: compounds 4, 2, 3 and 1 (each within the scatter of the next).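

At the place on a double-bonded chain carbon bound to a double-bonded chain carbon, this assay now shows 4-methoxyphenyl in place of 5-nitrothiophen-2-yl giving a 1.3-fold lower number from compound 3 to compound 4 (0.12 log units; within the scatter) and in place of furan-2-yl giving a 1.7-fold lower number from compound 1 to compound 4 (0.23 log units; within the scatter) so that neither replacement moves the number beyond the scatter. On an oxygen on an aromatic ring, methyl in place of trifluoromethyl gives a 1.2-fold lower number from compound 2 to compound 4 (0.09 log units; within the scatter) and so adds a second changed place that stays within the scatter.

From the compounds shown here alone, whether an amine or a carboxylic acid at the first place would also stay within the scatter remains open. Nothing available here accounts for these numbers.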